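The source may report more compounds than this note shows. Statements on the series, on what has been measured and on what is new or still open speak of the compounds shown alone.

Three compounds share one core and differ only in the group on the carbonyl carbon of the side chain. Compound 1 `O=C(NC[C@@H]1CCCc2cc(S(=O)(=O)c3cccc(F)c3)ccc21)c1ncc[nH]1` carries a 1H-imidazol-2-yl group there, and in an assay on isolated protein for displacement of a labelled ligand from 5-hydroxytryptamine receptor 6 (Homo sapiens) (a lower number here means a stronger inhibitor, a higher number a weaker inhibitor), compound 1 gives 15.9 nM. Compound 2 `O=C(NC[C@@H]1CCCc2cc(S(=O)(=O)c3cccc(F)c3)ccc21)[C@H]1CCCN1` carries pyrrolidin-2-yl, and in this assay compound 2 gives 0.631 nM, a change of a 25-fold lower number from compound 1 to compound 2 (1.40 log units; beyond the scatter). Compound 3 `NCC(=O)NC[C@@H]1CCCc2cc(S(=O)(=O)c3cccc(F)c3)ccc21` carries aminomethyl; in this assay compound 3 gives 0.316 nM, the lowest of the three numbers, with a 50-fold lower number from compound 1 to compound 3 (1.70 log units; beyond the scatter) and a 2.0-fold lower number from compound 2 to compound 3 (0.30 log units; within the scatter), so compound 3 and compound 2 cannot be separated.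

Compound 4 `CN(C)C(=O)NC[C@@H]1CCCc2cc(S(=O)(=O)c3cccc(F)c3)ccc21` is the next variation at the same position: dimethylamino in place of aminomethyl on a carbonyl carbon. The two large steps from compound 1 show that this position matters, while the step between compound 2 and compound 3 shows that two groups bearing a basic nitrogen give similar numbers. Compound 4 has no such group, so a move back toward compound 1 is expected, though smaller. Compound 4 is therefore estimated at 3.2 nM, within 0.6 nM to 16 nM, a step of a 10-fold higher number from compound 3 to compound 4 (1.01 log units; beyond the scatter).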

Compound 4, inhibition constant: 2.51 nM
Estimate against measurement, compound 4: 1.3-fold (0.11 log units) above; low and high end bracket the measured number.
By their numbers in this assay, from the lowest: compounds 3 and 2 (each within the scatter of the next); then compound 4; then compound 1.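

Dimethylamino fills the gap between the two groups at the low end and 1H-imidazol-2-yl, with a 7.9-fold higher number from compound 3 to compound 4 (0.90 log units; beyond the scatter) and a 4.0-fold higher number from compound 2 to compound 4 (0.60 log units; beyond the scatter), yet also a 6.3-fold lower number from compound 1 to compound 4 (0.80 log units; beyond the scatter). This position therefore gives at least three distinct levels rather than a simple split, and a group counted with no hydrogen-bond donor, unlike aminomethyl, still gives a lower number than 1H-imidazol-2-yl. No measurement shown here accounts for any of these steps. Still open, on these data alone, is where methylamino, with one methyl group on the nitrogen instead of two, would fall relative to compound 3 and compound 4. A longer chain such as 2-aminoethyl on the same carbonyl carbon would show whether the nitrogen can sit further out without moving the number.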